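The compounds below may be only part of what the source reports. "The series", "measured", "known", "first", "only" and "open" are said of these compounds alone.

Measured so far:
- compound 1, `Cn1ncc(Cl)c1-c1cc(C(=O)N[C@@H]2CNCC[C@H]2c2ccc(C(F)(F)F)cc2)oc1Cl`, 9.3 nM in an assay for inhibition of RAC-alpha serine/threonine-protein kinase (Homo sapiens), read by HTRF, with a stated time of 1 h; a higher number here means a weaker inhibitor, a lower number a stronger inhibitor
- compound 2, `Cn1ncc(Cl)c1-c1cc(C(=O)N[C@@H]2CN[C@H](CC(N)=O)C[C@H]2c2ccc(Cl)c(Cl)c2)oc1Cl`, 3.24 nM in this assay

Both compounds share the same core and differ at the saturated ring and the aryl group hanging from it. In this assay compound 2 gives 3.24 nM, the lowest of the two numbers, and compound 1 gives 9.3 nM; the gap between them lies beyond the usual scatter, so compound 2 is the stronger inhibitor of the pair.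

Compound 3, `Cn1ncc(Cl)c1-c1cc(C(=O)N[C@@H]2CN[C@H](CCO)C[C@H]2c2ccc(Cl)c(Cl)c2)oc1Cl`, is not yet measured. It differs from compound 2 in one place: hydroxymethyl in place of carbamoyl on a saturated chain carbon bound to a saturated ring carbon. Among the compounds with values here, no step between two measured compounds isolates this kind of change, so the expectation rests on the change alone. Both the leaving and the entering group carry one donor and one acceptor, so no large shift is expected; a modest step in the direction of a weaker inhibitor, within or near the scatter, is the estimate for the step of a 1.5-fold higher number from compound 2 to compound 3 (0.19 log units; within the scatter). Compound 3 is expected to give about 5 nM in this assay, in a range from 1.5 nM to 16 nM.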

Compound 3, half-maximal inhibitory concentration: 2.74 nM
Compound 3: middle estimate off by 1.8-fold (0.26 log units), on the high side; the measured number falls inside the stated range.
By their numbers in this assay, from the lowest: compounds 3 and 2 (each within the scatter of the next); then compound 1.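

Putting hydroxymethyl in place of carbamoyl on a saturated chain carbon bound to a saturated ring carbon gives a 1.2-fold lower number from compound 2 to compound 3 (0.07 log units; within the scatter) in this assay, so this measurement does not tell the two groups apart at this position. Compounds 1 and 2 differ in more than one place and could not show this, whereas this single change shows that the carbamoyl group is not required for a low number: with the difference read one bond further out, as carbamoylmethyl to 2-hydroxyethyl, compound 3 gives 2.74 nM. No measurement here bears on why the two groups give matching numbers.

The compounds shown leave open how much the end of this chain matters at all, and an amine, a carboxylic acid or a longer chain at the same place would test whether the number can move from this position. They also leave unseparated how much the saturated ring substituent and the aryl group each contribute to the gap between compound 1 and compound 2.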